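The source may report more compounds than this note shows. Statements on the series, on what has been measured and on what is new or still open speak of the compounds shown alone.

Compound 1 `O=C(Nc1cccc([N+](=O)[O-])c1)N1CCN(S(=O)(=O)c2sccc2-c2ccccc2Oc2ccc(O)c(O)c2)CC1`: > 20000 nM (a limit)
Compound 2 `O=C(Nc1ccc(F)cc1)N1CCN(S(=O)(=O)c2sccc2-c2ccccc2Oc2ccc(O)c(O)c2)CC1`: 15500 nM
Compound 3 `COc1ccc(Oc2ccccc2-c2ccsc2S(=O)(=O)N2CCN(C(=O)Nc3ccc([N+](=O)[O-])cc3)CC2)cc1OC`: > 20000 nM (a limit)

All three were tested in an ADME assay on HEK-293T cells (Homo sapiens) for cytotoxicity, read by CCK-8 assay, with a stated time of 48 h; a lower number here means a stronger inhibitor, a higher number a weaker inhibitor. Compound 3 stands at the limit of > 20000 nM in this assay, at which 2 of the 3 values shown sit, so it has a limit and no number. Compound 4 `O=C(Nc1ccc([N+](=O)[O-])cc1)N1CCN(S(=O)(=O)c2sccc2-c2ccccc2Oc2ccc(O)c(O)c2)CC1` differs from compound 3 in one place: 3,4-dihydroxyphenyl in place of 3,4-dimethoxyphenyl on an oxygen on an aromatic ring. Within the data shown here, no measured step makes this swap. Among the measured compounds shown here, the only measured step, an at least 1.2-fold lower number from compound 1 to compound 2 (0.11 log units; that floor lies within the scatter), changes another part of the molecule. Compound 2 already carries the 3,4-dihydroxyphenyl group and gives 15500 nM. The expected change is therefore none beyond the scatter, in either direction, and the estimated step is an at least 1.1-fold lower number from compound 3 to compound 4 (0.04 log units; that floor lies within the scatter). The estimate for compound 4 is 18000 nM, with an expected range of 9000 nM to 30000 nM.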

Compound 4, half-maximal inhibitory concentration: > 20000 nM
Compound 4 ended at the assay's limit (the forecaster's own chance of this, stated with the estimate: 55%); middle value at least 1.1-fold (0.04 log units) from the limit.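

In this assay compound 4 gives > 20000 nM, which is a limit and not a number, so the 3,4-dihydroxyphenyl group does not by itself give a measurable value here. Nitro in place of fluoro on an aromatic carbon gives an at least 1.2-fold higher number from compound 2 to compound 4 (0.11 log units; that floor lies within the scatter), so this change shows no separation beyond the scatter. The steps to compound 4 from compound 3 and compound 1 cannot be read, because both ends of each are limits: the limit of > 20000 nM in this assay, at which 3 of the 4 values shown sit.

As far as these compounds go, the effect of swapping 3,4-dimethoxyphenyl for 3,4-dihydroxyphenyl remains unknown. From the compounds shown here alone, whether an amine or a carboxylic acid in place of the nitro group would give a number also remains open.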